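A hydroxy(phenyl)methyl group replaces the sulfanyl side chain

This account rests on a few compounds, and the source may have more. Where it says the series, first, only, none or still open, it means among the compounds named here.

In a functional assay on RAW264.7 cells (Mus musculus) for inhibition, with stated times of 2 h and 24 h (a higher number here means a weaker inhibitor, a lower number a stronger inhibitor), compound 1 (`COc1ccc([C@@H]2c3c(OC)cc(OC)cc3C(SCc3ccc(C)cc3)[C@H]2c2cc(OC)cc(OC)c2)cc1`) gives > 200000 nM, which is a limit of the assay and not a number. Compound 2 (`COc1ccc([C@@H]2c3c(OC)cc(OC)cc3C(SCc3ccc(Cl)cc3)[C@H]2c2cc(OC)cc(OC)c2)cc1`) gives > 200000 nM, which is also a limit. For the measured compounds named here, the only measured evidence is the limit of > 200000 nM in this assay, at which 2 of the 2 values shown sit. Going by the values given here, the single measured step, a step that the two limits leave unreadable from compound 1 to compound 2, therefore offers no size to carry forward.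

Compound 3 (`COc1ccc([C@@H]2c3c(OC)cc(OC)cc3C(C(O)c3ccccc3)[C@H]2c2cc(OC)cc(OC)c2)cc1`) keeps the shared core but carries hydroxy(phenyl)methyl in place of (4-chlorobenzyl)sulfanyl on a saturated ring carbon. Among the compounds with values here, no measured step covers this exchange, so only a modest move towards stronger inhibition in this assay is expected, and another limit would be no surprise. The estimated change is an at least 1.3-fold lower number from compound 2 to compound 3 (0.12 log units; that floor lies within the scatter). For compound 3 the expected value is 150000 nM, with an estimated range of 40000 nM to 300000 nM.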

Compound 3, half-maximal inhibitory concentration: > 200000 nM
Compound 3 gave a limit, no number; the forecaster's own chance of this, stated with the estimate: 60%; middle value at least 1.3-fold (0.12 log units) away from the limit.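

In this assay compound 3 gives > 200000 nM, which is a limit of the assay and not a number. For the compounds shown here, no step among compound 1, compound 2 and compound 3 can therefore be read. The compounds shown leave open whether any change to the shared core would give a measurable half-maximal inhibitory concentration in this assay.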